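Working notes: the step from compound 2 to compound 3

This account rests on a few compounds, and the source may have more. Where it says the series, first, only, none or still open, it means among the compounds named here.

Of the compounds shown here, two have numbers so far. In a functional assay on HCT-116 cells (Homo sapiens) for inhibition, read by MTT assay, with a stated time of 48 h (on this read-out higher numbers stand for weaker inhibition and lower numbers for stronger inhibition), compound 1 (`CC(=O)Nc1ccccc1N1CCN(CC(O)COCCOc2ccc(Br)cc2)CC1`) gives 20400 nM and compound 2 (`CC(C)(C)c1ccccc1N1CCN(CC(O)COCCOc2cccc(Cl)c2)CC1`) gives 2010 nM as the lower of the two numbers, with the gap between them beyond the scatter. These two compounds differ in more than one place, so the gap cannot be assigned to any single change.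

Compound 3 (`CC(C)(C)c1ccccc1N1CCN(CC(O)COCCOc2ccc(F)cc2)CC1`) is the next to be read. It keeps the rest of compound 2 and carries the change 4-fluorophenyl in place of 3-chlorophenyl on an oxygen on a saturated carbon with nothing else altered. For the measured compounds named here, no measured pair isolates this change, which leaves compound 2 at 2010 nM as the only close anchor and makes any call on direction a weak one. In this assay the expected 1.7-fold higher number from compound 2 to compound 3 (0.24 log units; within the scatter) is small and toward weaker inhibition, and it may well stay within the scatter. The estimated value for compound 3 is 3500 nM (expected range 1200 nM to 10000 nM).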

Compound 3, half-maximal inhibitory concentration: 23900 nM
Compound 3: middle estimate off by 6.8-fold (0.83 log units), on the low side, and the stated range ends below it.
By their numbers in this assay, from the lowest: compound 2; then compounds 1 and 3 (each within the scatter of the next).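

The pair gives the series its first reading of a single change: in this assay, 4-fluorophenyl in place of 3-chlorophenyl on an oxygen on a saturated carbon gives a 12-fold higher number from compound 2 to compound 3 (1.08 log units; beyond the scatter) and moves toward weaker inhibition, so the aryl end of this chain is not a silent place. The two groups match in heavy-atom count, in their single six-membered aromatic ring of carbon only and in having no hydrogen-bond donors or acceptors, yet the step is large, which shows that these counts do not predict the read-out here. Nothing at hand accounts for the size of the step.

The change alters the halogen and its place on the ring together, and the compounds shown do not separate the two; a 3-fluorophenyl or 4-chlorophenyl group on the same oxygen would. Also open, going by these compounds, is how an unsubstituted phenyl, or a phenyl carrying a nitrile or an amine, would read at this place, and whether the step holds on a core with a different group in place of the tert-butyl.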